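This account rests on a few compounds, and the source may have more. Where it says the series, first, only, none or still open, it means among the compounds named here.

Measured so far in a functional assay on LS174T cells (Homo sapiens) for cytotoxicity; on this read-out higher numbers stand for weaker inhibition and lower numbers for stronger inhibition
compound 1 `Nc1cccc(SC(=O)NC(CCC(=O)O)C(=O)O)c1` gives > 5000000 nM
compound 2 `Nc1ccc(SC(=O)NC(CCC(=O)O)C(=O)O)cc1` gives 416000 nM
compound 3 `COc1ccc(SC(=O)N[C@@H](CCC(=O)O)C(=O)O)cc1` gives > 500000 nM

Compound 1 at > 5000000 nM is a limit of the assay, not a number. Within the data shown here, compound 2 at 416000 nM holds the only true number in the set. Compound 4 `Cc1ccc(SC(=O)NC(CCC(=O)O)C(=O)O)cc1` has methyl in place of amino on an aromatic carbon, para to a large group methyl in place of amino on an aromatic carbon in the structure. Compound 3, which also lacks the amino group, gives the limit > 500000 nM and is the basis for the expectation. The expected 1.2-fold higher number from compound 2 to compound 4 (0.08 log units; within the scatter) is small, towards weaker inhibition in this assay and possibly within the scatter. Compound 4 is estimated at 500000 nM with an expected range of 200000 nM to 1500000 nM here.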

Compound 4, half-maximal inhibitory concentration: > 500000 nM
Compound 4 ended at the assay's limit; the forecaster's own chance of this, stated with the estimate: 55%; the middle value lies on the limit itself.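

In this assay, among these compounds, methyl in place of amino on an aromatic carbon, para to a large group, gives the only readable step: an at least 1.2-fold higher number from compound 2 to compound 4 (0.07 log units; that floor lies within the scatter). That floor does not separate the two compounds, so the change may be small or large. The value of compound 4, > 500000 nM, is a limit and not a number, and the full size of the step stays unread because of where the values sit: the limit of > 500000 nM in this assay, at which 2 of the 4 values shown sit.

The compounds shown leave open how a hydroxyl or a dimethylamino group would read at this place. On these data alone, whether either would give a true number remains unknown.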